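A few compounds are considered here, and "the series" means these few. Any claim that something is new, unique, unknown or untested is made for them only; others in the source may bear on it.

Three compounds have been measured in an ADME assay on SK-OV-3 cells (Homo sapiens) for cytotoxicity, read by sulforhodamine B assay, with a stated time of 48 h, tested at 10 uM; on this read-out higher numbers stand for more inhibition at the one concentration tested (going by the name of the read-out) and lower numbers for less inhibition:

Compound 2 `CCCCc1cn(C(c2ccccc2)c2cc3cc(Br)ccc3nc2OC)nn1` gives 11.1%.
Compound 3 `CCCCCc1cn(C(c2ccccc2)c2cc3cc(Br)ccc3nc2OC)nn1` gives 10.5%.
Compound 1 `CCCCCCc1cn(C(c2ccccc2)c2cc3cc(Br)ccc3nc2OC)nn1` gives 7.17%.

Compound 2 carries the top number of the three, but this says little: the step of a number 0.6 percentage points lower from compound 2 to compound 3 (within the scatter) and the step of a number 3.9 percentage points higher from compound 1 to compound 2 (within the scatter) both fall within the usual scatter, so the three compounds cannot be told apart on these numbers. All three share one core and differ only in the length of the saturated chain on the triazole, and lengthening or shortening that chain by one or two carbons left the read-out essentially unchanged.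

Compound 4 `COc1nc2ccc(Br)cc2cc1C(c1ccccc1)n1cc(CCCCCO)nn1` is the next compound to be measured in this assay. Its change from compound 2 is hydroxymethyl in place of hydrogen on a saturated chain carbon, four bonds along the chain from an aromatic carbon. The measured steps that bear on it are the two that alter the same chain carbon, the step of a number 3.9 percentage points higher from compound 1 to compound 2 (within the scatter) and the step of a number 0.6 percentage points lower from compound 2 to compound 3 (within the scatter), and each was within the scatter. Going by the values given here, those steps only added or removed carbon, whereas this change brings in an oxygen-bearing group, for which there is no measured precedent here. On the evidence available, the expected step of a number 0.1 percentage points lower from compound 2 to compound 4 (within the scatter) is none beyond the scatter. Compound 4 is therefore estimated at 11%, with a range from 2% to 22%.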

Compound 4, a percentage reported as inhibition, at one concentration (the size of the read-out at that concentration, not a potency): 8.69%
The estimate for compound 4 lay 2.3 percentage points above the measured number, and the stated range covers the measured number.
By their numbers in this assay, from the lowest: compounds 1, 4, 3 and 2 (each within the scatter of the next).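

Bringing oxygen onto this chain did not set compound 4 apart from the compounds that carry only carbon there in this assay: hydroxymethyl in place of hydrogen gives a number 2.4 percentage points lower from compound 2 to compound 4 (within the scatter), hydroxy in place of hydrogen gives a number 1.8 percentage points lower from compound 3 to compound 4 (within the scatter), and hydroxy in place of methyl gives a number 1.5 percentage points higher from compound 1 to compound 4 (within the scatter). The earlier steps shown here had only added or removed carbon, so the new information is that a group with a hydrogen-bond donor and acceptor also stays within the usual scatter at this place on the chain, and the four compounds still cannot be told apart on this read-out. No separate measurement is available that would help to interpret this result.

Still open, going by these compounds, is whether a different group on this chain, such as an amine or a carboxylic acid, or a much longer chain, would give a step beyond the scatter. Also open, on these data alone, is how these compounds would compare at other concentrations, since all four numbers come from a single concentration and are not potencies.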